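Carboxylic acid to methyl ketone on the imidazole chain

The source may hold more compounds than are shown below. What is called first, only, known or untested is meant among the compounds shown, and "the series" means these compounds.

Measured compounds:
compound 1, `C=CCn1c(=O)c2[nH]cnc2n(CCC)c1=O`, 1600 nM
compound 2, `CCCn1c(=O)n(CCC(C)=O)c(=O)c2[nH]cnc21`, 3500 nM
compound 3, `CCCn1c(=O)n(C)c(=O)c2c1ncn2CCC(=O)O`, > 100000 nM

Compound 3 stands apart from the other two. In a functional assay (trachea) with Cavia porcellus as the target (a lower number here means that less compound is needed, a higher number that more compound is needed for the effect), compound 3 gives only a limit, > 100000 nM, and this is where the limit of > 100000 nM in this assay, at which 1 of the 3 values shown sits, sits. Among the compounds with values here, compound 1 gives 1600 nM and compound 2 gives 3500 nM; the single measured step, a 2.2-fold higher number from compound 1 to compound 2 (0.34 log units; beyond the scatter), concerns a chain on a different aromatic nitrogen and does not measure the change now at hand.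

Compound 4, `CCCn1c(=O)n(C)c(=O)c2c1ncn2CCC(C)=O`, differs from compound 3 by methyl in place of hydroxy on a carbonyl carbon. Within the data shown here, no measured step carries this change, so the direction of an at least 5.0-fold lower number from compound 3 to compound 4 (0.69 log units; beyond the scatter) can only be an expectation and is taken as a lowering of the number, since compound 2, which also carries a ketone chain, gives 3500 nM. Compound 3, by contrast, gives only a limit in this assay. The estimate for compound 4 in this assay is 20000 nM, with a range from 4000 nM to 100000 nM.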

Compound 4, half-maximal effective concentration: 12200 nM
Beside the measured number, compound 4's estimate is 1.6-fold (0.21 log units) above it; the range from low to high includes it.
By their numbers in this assay, from the lowest: compound 1; then compound 2; then compound 4. At a limit, above all of these: compound 3.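

Within the data shown here, on the imidazole-side chain, methyl in place of hydroxy on a carbonyl carbon gives an at least 8.1-fold lower number from compound 3 to compound 4 (0.91 log units; beyond the scatter) in this assay, the first measured reading of this change. The size of that step is only a bound, since the value of compound 3 is a limit of the assay and not a number: the limit of > 100000 nM in this assay, at which 1 of the 4 values shown sits. The acetyl form thus brings this chain from a limit to a measured value, with a hydrogen-bond donor leaving along with the hydroxy.

The compounds shown do not separate the loss of that hydroxy from the arrival of the methyl carbon, and a methyl ester or a primary amide in place of hydroxy on this carbonyl carbon could address that. On these data alone, how an amine or a longer chain would read in this assay also stays open.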